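Extending a Thiourea Chain by One Carbon

The compounds below may be only part of what the source reports. "The series", "measured", "known", "first", "only" and "open" are said of these compounds alone.

Of the compounds shown here, two have been tested in a functional assay on the whole organism (strain Swiss albino) with Mus musculus as the target, in the maximal electroshock model, with a stated time of 0.5 h; a higher number here means that more compound is needed for the effect, a lower number that less compound is needed. Compound 1 `COc1cc2c(cc1OC)C(=O)C(CC1CCN(C(=S)Nc3cccc([N+](=O)[O-])c3)CC1)C2` gives 300 mg/kg. Compound 2 `CCCNC(=S)N1CCC(CC2Cc3cc(OC)c(OC)cc3C2=O)CC1` gives 100 mg/kg. For the measured compounds named here, the single measured step, a 3.0-fold lower number from compound 1 to compound 2 (0.48 log units; beyond the scatter), shows that the propyl thiourea required less compound than its 3-nitrophenyl counterpart. Going by the values given here, on these two numbers compound 2 stands lowest, with compound 1 as its only neighbour at a higher dose.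

Compound 3 `CCCCNC(=S)N1CCC(CC2Cc3cc(OC)c(OC)cc3C2=O)CC1` is not yet measured. It differs from compound 2 by methyl in place of hydrogen on a saturated chain carbon, three bonds along the chain from an amide-type nitrogen. Among the compounds with values here, no measured step concerns a change of this kind: the step from compound 1 to compound 2 swaps an aromatic group for a chain, and it says nothing about lengthening an existing chain by one carbon. Without such guidance, the step from compound 2 to compound 3 is expected to stay within the scatter, as no change at the digits printed from compound 2 to compound 3 (within the scatter). Compound 3 is therefore estimated at 100 mg/kg in this assay, with a range from 30 mg/kg to 300 mg/kg.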

Compound 3, minimum effective dose: 100 mg/kg
Beside the measured number, compound 3's estimate shows no gap at the digits printed; the measured number falls inside the stated range.
By their numbers in this assay, from the lowest: compounds 2 and 3 (each within the scatter of the next); then compound 1.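

In this assay this position on the thiourea chain accepts methyl in place of hydrogen, the change from propyl to butyl, with no change at the digits printed from compound 2 to compound 3 (within the scatter) as its result, so one added carbon at this point does not separate the two chains. The earlier step compared a chain only with an aromatic group, and the butyl chain now gives the same kind of result with a 3.0-fold lower number from compound 1 to compound 3 (0.48 log units; beyond the scatter), so both the propyl and the butyl thioureas stand apart from the 3-nitrophenyl thiourea of compound 1. No supporting data are available to explain why the dose stays the same across this change in chain length.

Going by these compounds, whether the same holds further out stays open, since a longer chain such as hexyl, a branched chain such as isopropyl, or a ring such as cyclohexyl could behave differently from propyl and butyl. On these data alone, it is also open whether the higher dose of compound 1 belongs to aromatic groups in general or to this one, which an unsubstituted phenyl or a 3-methoxyphenyl group in the same place would help to show.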